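Trimming the side chain in a thymine-bearing piperidine series

The source may report more compounds than this note shows. Statements on the series, on what has been measured and on what is new or still open speak of the compounds shown alone.

Compound 2 `Cc1cn([C@H]2CCCN([C@@H](CC(C)C)c3ccc(C(=O)O)c(Oc4cccc(Cl)c4)c3F)C2)c(=O)[nH]c1=O` and compound 3 `CCC[C@@H](c1ccc(C(=O)O)c(Oc2cccc(Cl)c2)c1F)N1CCC[C@H](n2cc(C)c(=O)[nH]c2=O)C1` share a core and differ only by hydrogen in place of methyl on a saturated chain carbon bound to two saturated chain carbons. In an ADME assay on the whole organism (strain Wistar) for pharmacokinetics, with Rattus norvegicus as the target, given by the intravenous route (on this read-out lower numbers stand for slow clearance and higher numbers for fast clearance), compound 2 gives 38 mL/min/kg, while compound 3 gives 18 mL/min/kg, so that the step of a 2.1-fold lower number from compound 2 to compound 3 (0.32 log units; beyond the scatter). In this assay compound 1 `CCC[C@@H](c1ccc(C(=O)O)c(Oc2cccc(Cl)c2)c1OC)N1CCC[C@H](n2cc(C)c(=O)[nH]c2=O)C1` gives "not determined" (no result reported). Compound 4 `CC[C@@H](c1ccc(C(=O)O)c(Oc2cccc(Cl)c2)c1OC)N1CCC[C@H](n2cc(C)c(=O)[nH]c2=O)C1` differs from compound 1 by hydrogen in place of methyl on a saturated chain carbon, three bonds along the chain from an amine nitrogen in a ring and an aromatic carbon; this is the same kind of change as that from compound 2 to compound 3, though the surroundings of the place differ, one being three bonds along the chain from an amine nitrogen in a ring and an aromatic carbon, the other bound to two saturated chain carbons. The difference between the two cores is not broken down here. Because compound 3 gives 18 mL/min/kg, and the shortening of the chain lowered the number there, compound 4 is expected to show a similar or somewhat lower clearance, estimated at 15 mL/min/kg, within 7 mL/min/kg to 35 mL/min/kg.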

Compound 4, clearance: 73 mL/min/kg
Beside the measured number, compound 4's estimate is 4.9-fold (0.69 log units) below it; measured number outside the range, above it.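

In this assay, for the compounds shown here, compound 1 gives "not determined" (no result reported), so no step from compound 1 to compound 4 can be read. What the propyl to ethyl change does on this core stays open, and no supporting data explain the value of compound 4.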